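Swapping a Carbamate Tail for a Dithiocarbamate

The source may report more compounds than this note shows. Statements on the series, on what has been measured and on what is new or still open speak of the compounds shown alone.

Within the data shown here, compound 3 `CSC(=O)N1CCC(Oc2ncnc3c2CCN3c2ccc(S(C)(=O)=O)cc2F)CC1` is the weakest of the three compounds measured so far: in a functional assay on CHO-K1 cells for agonist activity at Glucose-dependent insulinotropic receptor (Homo sapiens), read by a luciferase reporter, with a stated time of 5 h (on this read-out higher numbers stand for an effect only at larger amounts of compound and lower numbers for an effect already at smaller amounts), compound 3 gives 251 nM. Compound 1 `CCCOC(=O)N1CCC(Oc2ncnc3c2CCN3c2ccc(S(C)(=O)=O)cc2F)CC1` gives 79.4 nM and compound 2 `CC(C)COC(=O)N1CCC(Oc2ncnc3c2CCN3c2ccc(S(C)(=O)=O)cc2F)CC1` gives 25.1 nM; both differ from compound 3 only in the group on the carbonyl carbon, and the relevant steps were a 3.2-fold higher number from compound 1 to compound 3 (0.50 log units; beyond the scatter) and a 10-fold higher number from compound 2 to compound 3 (1.00 log units; beyond the scatter). Compound 4 `CS(=O)(=O)c1ccc(N2CCc3c(OC4CCN(C(=S)Sc5ccccc5)CC4)ncnc32)c(F)c1` alters that same attachment point more drastically: a group of 9 heavy atoms (7 carbon, 2 sulfur; one six-membered aromatic ring of carbon only) in place of a group of 4 heavy atoms (2 carbon, 1 oxygen, 1 sulfur; no ring), on an amine nitrogen in a ring. A modest shift toward a lower number is expected, because a 3.2-fold higher number from compound 1 to compound 3 (0.50 log units; beyond the scatter) and a 10-fold higher number from compound 2 to compound 3 (1.00 log units; beyond the scatter) both ran toward higher numbers when the group was cut down. Compound 4 is therefore estimated at 120 nM in this assay, within a plausible range of 30 nM to 500 nM. That estimate corresponds to an expected step of a 2.1-fold lower number from compound 3 to compound 4 (0.32 log units; beyond the scatter).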

Compound 4, half-maximal effective concentration: 12.6 nM
For compound 4 the middle estimate is 9.5-fold (0.98 log units) above the measured one; the whole stated range lies above it.
By their numbers in this assay, from the lowest: compounds 4 and 2 (each within the scatter of the next); then compound 1; then compound 3.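

Among these compounds, on this amine nitrogen in a ring, the earlier compounds carried only groups without a ring, and a group with one six-membered aromatic ring of carbon only is clearly accepted in this assay, giving a 20-fold lower number from compound 3 to compound 4 (1.30 log units; beyond the scatter). Against the carbamates the picture splits, with a 6.3-fold lower number from compound 1 to compound 4 (0.80 log units; beyond the scatter) but only a 2.0-fold lower number from compound 2 to compound 4 (0.30 log units; within the scatter), so this larger group and the isobutoxy carbamate cannot be told apart here. Nothing available explains these shifts. As far as these compounds go, compound 4 brings in a thiocarbonyl and the aromatic ring together, so the share of each remains open. A phenoxycarbonyl group would help separate them.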